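This account rests on a few compounds, and the source may have more. Where it says the series, first, only, none or still open, it means among the compounds named here.

Measured compounds:
compound 1 `CCCCOC(=O)Nc1ccc2cnn(Cc3ccc(C(=O)NS(=O)(=O)c4ccccc4)cc3OC)c2c1` — 9.2
compound 2 `COc1cc(C(=O)NS(=O)(=O)c2cc(C)ccc2C)ccc1Cn1ccc2ccc(NC(=O)CC3CCCC3)cc21` — 8.4

Both values come from a functional assay (trachea) for antagonist activity, with Cavia porcellus as the target; a lower number here means a less potent compound, a higher number a more potent compound, by a factor of ten per unit of this negative logarithm. Compound 2 stands lowest of the two; compound 1 lies higher by a margin beyond the usual scatter. Compound 3 `COc1cc(C(=O)NS(=O)(=O)c2ccc3ccccc3c2)ccc1Cn1ccc2ccc(NC(=O)CC3CCCC3)cc21` is compound 2 with naphthalen-2-yl in place of 2,5-dimethylphenyl on a sulfonyl sulfur. For the measured compounds named here, no pair of measured compounds differs in one place, so nothing measured here bears directly on this change. In this assay the expected step is a number 0.10 log units higher from compound 2 to compound 3 (within the scatter), small and probably not beyond the scatter, with slight room upward. Compound 3 is accordingly estimated at 8.5, with a range from 7.9 to 9.1.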

Compound 3, negative logarithm of the antagonist equilibrium constant: 8.3
Estimate against measurement, compound 3: 0.20 log units above; the range from low to high includes it.
By their numbers in this assay, from the lowest: compounds 3 and 2 (each within the scatter of the next); then compound 1.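

In this assay, naphthalen-2-yl in place of 2,5-dimethylphenyl on a sulfonyl sulfur gives a number 0.10 log units lower from compound 2 to compound 3 (within the scatter). For the compounds shown here, this is the first single-change reading at this position, and it does not separate the two groups: a second six-membered aromatic ring of carbon only leaves compound 2 and compound 3 indistinguishable in this read-out. No available data explain this result.

On these data alone, whether the same holds for a pentyl chain or a carboxylic acid-bearing phenyl on the sulfonyl sulfur remains open. Compound 1 differs from these compounds in more than one place and cannot settle this.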